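A few compounds are considered here, and "the series" means these few. Any claim that something is new, unique, unknown or untested is made for them only; others in the source may bear on it.

Within the data shown here, compound 2 `CC1CCN(C2CCN(S(=O)(=O)c3cccc(Br)c3)CC2)CC1` gives 1.2 nM in a functional assay on HT-29 cells (Homo sapiens) for antiproliferative activity, read by CellTiter-Glo, with a stated time of 72 h (on this read-out higher numbers stand for weaker inhibition and lower numbers for stronger inhibition), the lower of the two numbers so far. Compound 1 `CC1CCN(C2CCN(S(=O)(=O)c3ccccc3Br)CC2)CC1` gives 3 nM in this assay, and the step of a 2.5-fold lower number from compound 1 to compound 2 (0.40 log units; beyond the scatter) is the only measured move in the set. Compound 3 `CC1CCN(C2CCN(S(=O)(=O)c3cccc(-c4ccccc4)c3)CC2)CC1` differs from compound 2 by phenyl in place of bromo on an aromatic carbon. Among the measured compounds shown here, no measured step concerns a bromo-to-phenyl exchange, and the single step measured concerns only where the bromo sits, so it offers little guidance. A step within the scatter is expected, in either direction, giving a 1.7-fold higher number from compound 2 to compound 3 (0.22 log units; within the scatter). Compound 3 is expected to give 2 nM, within 0.5 nM to 8 nM.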

Compound 3, half-maximal inhibitory concentration: 2 nM
The estimate for compound 3 equals the measured number at the digits printed; the measured number falls inside the stated range.
By their numbers in this assay, from the lowest: compounds 2, 3 and 1 (each within the scatter of the next, the first and the last beyond it).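

At this position, on an aromatic carbon meta to a large group, the step from bromo to phenyl gives a 1.7-fold higher number from compound 2 to compound 3 (0.22 log units; within the scatter) in this assay and does not separate the two compounds. The position therefore accepts a whole six-membered aromatic ring of carbon only, not just a single bromine atom, with the number staying in the same range. As far as these compounds go, whether an amine or a carboxylic acid on that new phenyl ring, or a longer chain at the same carbon, would hold this number remains open. No available data explain this result.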